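The compounds below may be only part of what the source reports. "The series", "measured", "known", "first", "only" and "open" are said of these compounds alone.

Compound 1, with the structure `NNC(=O)COc1ccncc1-c1ccc2ccccc2c1`, has no number of its own in an assay on a protein complex for inhibition of CDK8/Cyclin C (Homo sapiens), with a stated time of 1 h (on this read-out lower numbers stand for stronger inhibition and higher numbers for weaker inhibition), where compound 1 is recorded as "not determined" (no result reported), so there is nothing to say about where it stands. Two other compounds built on the same core do carry numbers. Compound 2, `CN1CCN(C(=O)/C=C/c2ccncc2-c2ccc(F)cc2)CC1`, gives 1210 nM in this assay. Compound 3, `CCOC(=O)/C=C/c1ccncc1-c1ccc2c(ccn2C)c1`, gives 144 nM in this assay, a stronger result than that of compound 2. Compound 4, `CNC(=O)CCc1ccncc1-c1ccc2ccccc2c1`, has not yet been measured in this assay. The change from compound 1 to compound 4 is 2-(methylcarbamoyl)ethyl in place of (aminocarbamoyl)methoxy on an aromatic carbon. Among the measured compounds shown here, no measured pair shows this change, so the size and direction of the step cannot be read from the data; the two measured compounds only show that side chains of this general kind can reach results anywhere from the weaker value of compound 2 to the stronger value of compound 3. On that basis compound 4 is expected to land near 500 nM, with a range from 100 nM to 3000 nM.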

Compound 4, half-maximal inhibitory concentration: 21.1 nM
Estimate against measurement, compound 4: 24-fold (1.37 log units) above; the measured number lies below the stated range.
By their numbers in this assay, from the lowest: compound 4; then compound 3; then compound 2.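

No step can be read from compound 1 to compound 4, nor between compound 4 and compound 2 or compound 3. The compounds shown leave open what the 2-(methylcarbamoyl)ethyl group itself contributes in this assay. Nothing shown here bears on a cause.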